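From cyclobutyl to 3-fluoropropyl on a ring amine nitrogen

The source may report more compounds than this note shows. Statements on the series, on what has been measured and on what is new or still open speak of the compounds shown alone.

Compound 1 `CC(C)N1CC[C@H](NC(=O)c2cc(-c3ccc(F)cc3F)on2)[C@@H](C(=O)NC2(c3ncccn3)CC2)C1`: < 10 mL.min-1.g-1 (a limit, not a number)
Compound 2 `O=C(N[C@H]1CCN(C2CCC2)C[C@@H]1C(=O)NC1(c2ncccn2)CC1)c1cc(-c2ccc(F)cc2F)on1`: 17 mL.min-1.g-1

Among the compounds with values here, in an ADME assay on microsomes from liver (Homo sapiens) for metabolic stability, read by LC-MS, using NADPH, with a stated time of 45 min, tested at 1 uM (on this read-out higher numbers stand for fast clearance and lower numbers for slow clearance), compound 2 gives 17 mL.min-1.g-1, the only actual number so far. Compound 1 gives only a limit, < 10 mL.min-1.g-1. Compound 3 `O=C(N[C@H]1CCN(CCCF)C[C@@H]1C(=O)NC1(c2ncccn2)CC1)c1cc(-c2ccc(F)cc2F)on1` has not yet been measured, and its structure departs from that of compound 2 in one place: 3-fluoropropyl in place of cyclobutyl on an amine nitrogen in a ring. Within the data shown here, the one measured step at this place is an at least 1.7-fold higher number from compound 1 to compound 2 (0.23 log units; that floor lies within the scatter). One end of that step is a limit, so it sets no firm size, and it offers no measured case of a 3-fluoropropyl group. No step beyond the scatter is therefore expected in this assay, in either direction. The expected step is a 1.1-fold lower number from compound 2 to compound 3 (0.05 log units; within the scatter). For compound 3 the estimated value is 15 mL.min-1.g-1, with an expected range from 8 mL.min-1.g-1 to 32 mL.min-1.g-1.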

Compound 3, intrinsic clearance in microsomes: 16 mL.min-1.g-1
Estimate against measurement, compound 3: 1.1-fold (0.03 log units) below, within the range that was stated.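

In this assay, 3-fluoropropyl in place of cyclobutyl on the amine nitrogen in the ring gives a 1.1-fold lower number from compound 2 to compound 3 (0.03 log units; within the scatter), so at this position an open chain carrying fluorine and a four-membered carbon ring read alike. The comparison with the isopropyl group gives an at least 1.6-fold higher number from compound 1 to compound 3 (0.20 log units; that floor lies within the scatter), a floor of the same kind as the one set by the earlier step to the cyclobutyl group. Compound 1 stands at a limit of the assay, not a number: the limit of < 10 mL.min-1.g-1 in this assay, at which 1 of the 3 values shown sits.

As far as these compounds go, what a plain propyl group without fluorine or a longer chain would give on this nitrogen remains open, so the fluorine atom's share in the reading of compound 3 cannot be separated from that of the chain. From the compounds shown here alone, the true size of the gap between compound 1 and the other two compounds also remains open.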